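Methoxycarbonyl to Isobutoxycarbonyl: Expecting a Small Step

The compounds below may be only part of what the source reports. "The series", "measured", "known", "first", "only" and "open" are said of these compounds alone.

Two compounds share one core. Compound 1 `CCCCCC(=O)c1ccc(OCCCN2CCNCC2)cc1` carries a hydrogen on an amine nitrogen in a ring, and in an assay on isolated protein for binding affinity to histamine H2 receptor (Homo sapiens) (a lower number here means a stronger inhibitor, a higher number a weaker inhibitor), compound 1 gives 14500 nM. Compound 2 `CCCCCC(=O)c1ccc(OCCCN2CCN(C(=O)OC)CC2)cc1` carries a methoxycarbonyl there instead, and in this assay compound 2 gives 12000 nM. That replacement produced a 1.2-fold lower number from compound 1 to compound 2 (0.08 log units; within the scatter), so compound 2 stands with compound 1 inside the scatter and the two cannot be told apart on these numbers. Compound 3 `CCCCCC(=O)c1ccc(OCCCN2CCN(C(=O)OCC(C)C)CC2)cc1` extends the same group: isopropyl in place of hydrogen on a saturated chain carbon bound to an oxygen next to a carbonyl group, so that methoxycarbonyl becomes isobutoxycarbonyl. For the measured compounds named here, no measured pair covers an extension of this kind; the only step seen here, which attached the whole methoxycarbonyl, stayed within the scatter. The expectation for compound 3 is therefore a step of a 1.3-fold lower number from compound 2 to compound 3 (0.12 log units; within the scatter), modest at most. Compound 3 is estimated at 9000 nM, with a range from 3000 nM to 30000 nM.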

Compound 3, inhibition constant: 3720 nM
Compound 3: the middle estimate sits 2.4-fold (0.38 log units) above what was measured; the range from low to high includes it.
By their numbers in this assay, from the lowest: compound 3; then compounds 2 and 1 (each within the scatter of the next).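

Isopropyl on the saturated chain carbon bound to an oxygen next to a carbonyl group gives a 3.2-fold lower number from compound 2 to compound 3 (0.51 log units; beyond the scatter) in this assay and is the first step here to lie beyond the scatter. Measured from the amine hydrogen, isobutoxycarbonyl gives a 3.9-fold lower number from compound 1 to compound 3 (0.59 log units; beyond the scatter) even though methoxycarbonyl could not be told apart from that hydrogen, so among these three compounds the outer part of the group decides whether the number moves, not the carbonyl alone. No supporting measurement is available to explain this fall.

The compounds shown leave open whether ethoxycarbonyl would fall between methoxycarbonyl and isobutoxycarbonyl, and whether a straight butoxycarbonyl would match the branched isobutoxycarbonyl. They also leave open whether a longer chain or a benzyloxycarbonyl would lower the number further.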